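Propyl chain extension in the pyridine-tetrazole amide series

The source may hold more compounds than are shown below. What is called first, only, known or untested is meant among the compounds shown, and "the series" means these compounds.

Measured so far:
Compound 1 `COc1cc(C(=O)Nc2nn[nH]n2)nc(-c2ccccc2)c1` — 100%
Compound 2 `CCc1cc(C(=O)Nc2nn[nH]n2)nc(-c2ccccc2)c1` — 85%

In a functional assay on the whole organism for inhibition, with Rattus norvegicus as the target, at a dose of 10 mg/kg by the oral route (on this read-out lower numbers stand for a weaker effect and higher numbers for a stronger effect at the one dose given), compound 1 gives 100% and compound 2 gives 85%. Among the measured compounds shown here, on these two numbers compound 2 stands lowest; its nearest neighbour is compound 1, and the only measured step is a number 15 percentage points lower from compound 1 to compound 2 (beyond the scatter).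

Compound 3 `CCCc1cc(C(=O)Nc2nn[nH]n2)nc(-c2ccccc2)c1` is not yet measured. It differs from compound 2 by methyl in place of hydrogen on a saturated chain carbon, two bonds along the chain from an aromatic carbon. For the measured compounds named here, no measured step matches this change directly. Going by the values given here, the one step in hand, ethyl in place of methoxy, ran to a lower number, and a second lengthening of the same chain is the nearest comparison available, though it does not replace an acceptor-bearing group. A further modest lowering is therefore expected, though one that may not clear the scatter. For compound 3 the expected step is a number 10 percentage points lower from compound 2 to compound 3 (within the scatter), giving an estimate of 75% with a range from 50% to 95%.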

Compound 3, a percentage reported as inhibition, in the whole organism at one dose (the size of the read-out at that dose, not a potency): 85%
For compound 3 the middle estimate is 10 percentage points below the measured one; measured number inside the range.
By their numbers in this assay, from the lowest: compounds 2 and 3 (each within the scatter of the next); then compound 1.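

In this assay, going from ethyl to propyl on this aromatic carbon gives no change at the digits printed from compound 2 to compound 3 (within the scatter), so the added methyl on a saturated chain carbon, two bonds along the chain from an aromatic carbon, leaves the read-out where it was. Propyl in place of methoxy gives a number 15 percentage points lower from compound 1 to compound 3 (beyond the scatter), so the gap to the methoxy compound stays the same size with either chain, and chain length between ethyl and propyl does not separate these compounds. No evidence at hand accounts for this gap or for the flat step between the two chains.

Still open, from the compounds shown here alone, is whether a butyl chain or an isopropyl group on the same carbon would stay level with compound 3, and whether an ethoxy group or an amine there would come back towards compound 1 at 100%. With a single dose for each compound, the read-out shows only the stronger or weaker effect at that dose and says nothing about how the compounds would compare at other doses.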